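Two Stereocentres Swapped in a Cyclic Peroxide Acid

The source may report more compounds than this note shows. Statements on the series, on what has been measured and on what is new or still open speak of the compounds shown alone.

Of the compounds shown here, three have been measured in a functional assay on CAKI-1 cells (Homo sapiens) for inhibition; a lower number here means a stronger inhibitor of growth, a higher number a weaker inhibitor of growth. Compound 1 `CC(=O)CC/C=C(\C)CCC1=C(C)CCCC1(C)C` reaches only the limit of the assay, giving > 15000 nM in this assay; that is a limit, not a number. Compound 2 `C=C1CCC[C@H]2[C@](C)(CC[C@]3(C)CC[C@H]([C@@H](C)C(=O)O)OO3)[C@@H](C)CC[C@]12C` gives 1760 nM in this assay. Compound 3 `C=C1CCCC(C)(C)C1CC[C@@]1(C)CC[C@H]([C@@H](C)C(=O)O)OO1` gives 2000 nM in this assay, and its value and that of compound 2 sit within the usual scatter of each other, so no order between them can be read.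

The piece now follows the step from compound 3 to compound 4 `C=C1CCCC(C)(C)C1CC[C@]1(C)CC[C@@H]([C@@H](C)C(=O)O)OO1`. The two differ only in stereochemistry: the two compounds have the same atoms and bonds; at least one stereo element is drawn with a configuration in one of them and without one in the other: 2 of 4 stereo elements differ; a stereocentre at a saturated ring carbon is drawn S in compound 3 and R in compound 4; a stereocentre at a saturated ring carbon is drawn R in compound 3 and S in compound 4

Going by the values given here, no step between measured compounds is available to guide this, so the expectation rests on the change alone. A modest weakening in this assay is expected, since the step from compound 3 to compound 4 is estimated at a 1.8-fold higher number from compound 3 to compound 4 (0.24 log units; within the scatter), though the true value could fall on either side of the scatter. Compound 4 is therefore expected to give about 3500 nM in this assay, with a range from 1000 nM to 12000 nM.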

Compound 4, concentration for 50% growth inhibition: > 10000 nM
Compound 4 was reported as a limit; the forecaster's own chance of this, stated with the estimate: 15%; middle value at least 2.8-fold (0.45 log units) away from the limit.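

In this assay compound 4 gives > 10000 nM, which is a limit and not a number. Going by these compounds alone, the atoms and bonds stay the same and only two stereocentres at saturated ring carbons change, one from S to R and the other from R to S, yet this gives an at least 5.0-fold higher number from compound 3 to compound 4 (0.69 log units; beyond the scatter), the first step that can be read in this set and one that shows the drawn arrangement at these two ring carbons matters for growth inhibition. The size of that step is only a lower bound, not a measured gap: the limit of > 10000 nM in this assay, at which 1 of the 4 values shown sits.

The compounds shown leave open whether one of the two ring carbons alone accounts for the weakening, or whether both are needed. From the compounds shown here alone, it also remains open whether the same swap would matter as much with a methyl ester in place of the carboxylic acid.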